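The source may report more compounds than this note shows. Statements on the series, on what has been measured and on what is new or still open speak of the compounds shown alone.

Of the compounds shown here, three have so far been measured in a physicochemical assay for lipophilicity, read by HPLC, at pH 7.4; a lower number here means a more polar compound, a higher number a more lipophilic compound. Compound 1 `C[C@@H](Oc1cc2cnn(CCC(=O)O)c2cc1Cl)c1ccccn1` gives 1.7, compound 2 `C[C@@H](Oc1cc2ccn(CCC(=O)O)c2cc1Cl)c1ccccn1` gives 2.17, and compound 3 `Cc1ccc([C@@H](C)Oc2cc3oc(=O)n(CCC(=O)O)c3cc2Cl)nc1` gives 2.02. Compound 3 thus stands second highest of the three: its number sits close to that of compound 2, within the usual scatter, and lies beyond the scatter above that of compound 1.

Compound 4 `C[C@@H](Oc1cc2oc(=O)n(CCC(=O)O)c2cc1Cl)c1ncccn1` has not yet been measured. It differs from compound 3 in one place: pyrimidin-2-yl in place of 5-methylpyridin-2-yl on a saturated chain carbon bound to an oxygen on an aromatic ring and a saturated chain carbon. For the measured compounds named here, no measured pair shows this same change, so its size has to be estimated. The entering group has fewer carbon atoms and more nitrogen atoms than the leaving group, and a step down in this assay beyond the scatter is expected, a number 0.92 log units lower from compound 3 to compound 4 (beyond the scatter). Compound 4 is expected to give about 1.1, within a range from 0.6 to 1.6.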

Compound 4, distribution coefficient: 0.83
For compound 4 the middle estimate is 0.27 log units above the measured one, and the stated range covers the measured number.
By their numbers in this assay, from the lowest: compound 4; then compound 1; then compounds 3 and 2 (each within the scatter of the next).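

Pyrimidin-2-yl in place of 5-methylpyridin-2-yl on the saturated chain carbon gives the first step that can be read at this position: in this assay it is a number 1.19 log units lower from compound 3 to compound 4 (beyond the scatter) and is large. The swap removes the methyl group and adds a ring nitrogen together, so this one pair cannot divide the step between those two changes. No measurement on hand explains the size of the step.

As far as these compounds go, it remains open where a phenyl ring, or a pyridine ring carrying an amine, would fall on this carbon with the rest of the compound unchanged.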